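Aryloxy Change on a Thromboxane Synthase Inhibitor Scaffold

The source may hold more compounds than are shown below. What is called first, only, known or untested is meant among the compounds shown, and "the series" means these compounds.

Compound 1: `CC(C)(C)c1ccc(OC(C)(C)C2OCC(C/C=C\CCC(=O)O)C(c3cccnc3)O2)cc1`, 280 nM
Compound 2: `Cc1ccc(OC(C)(C)C2OCC(C/C=C\CCC(=O)O)C(c3cccnc3)O2)cc1`, 360 nM

In an assay for inhibition of Thromboxane-A synthase (Homo sapiens), using microsomes (a higher number here means a weaker inhibitor, a lower number a stronger inhibitor), compound 1 gives 280 nM and compound 2 gives 360 nM; the two sit within the scatter of each other, as the step of a 1.3-fold higher number from compound 1 to compound 2 (0.11 log units; within the scatter) shows. Compound 3, `CC(C)(Oc1ccccc1Br)C1OCC(C/C=C\CCC(=O)O)C(c2cccnc2)O1`, differs from compound 2 by 2-bromophenyl in place of 4-methylphenyl on an oxygen on a saturated carbon. Among the measured compounds shown here, the only measured step changes a different substituent on the same phenoxy group and was small, so no shift beyond the scatter is expected for compound 3, estimated at 350 nM (range 150 nM to 900 nM). That estimate corresponds to a step of a 1.0-fold lower number from compound 2 to compound 3 (0.01 log units; within the scatter).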

Compound 3, half-maximal inhibitory concentration: 29 nM
For compound 3 the middle estimate is 12-fold (1.08 log units) above the measured one; the measured number lies below the stated range.
By their numbers in this assay, from the lowest: compound 3; then compounds 1 and 2 (each within the scatter of the next).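

In this assay the aryl group on this oxygen proves able to move the number well beyond the scatter: 2-bromophenyl in place of 4-methylphenyl gives a 12-fold lower number from compound 2 to compound 3 (1.09 log units; beyond the scatter) while the earlier exchange of methyl for tert-butyl did not. Set against 4-(tert-butyl)phenyl, the same group gives a 9.7-fold lower number from compound 1 to compound 3 (0.98 log units; beyond the scatter) so the gain holds against both earlier compounds. No evidence is at hand that bears on this result. The compounds shown leave open whether the bromine itself or its place on the phenyl ring carries the gain, and whether a chlorine atom or an amine in its stead would keep it.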